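The source may hold more compounds than are shown below. What is called first, only, known or untested is meant among the compounds shown, and "the series" means these compounds.

Of the compounds shown here, three built on one shared core have been measured in a physicochemical assay for lipophilicity; a higher number here means a more lipophilic compound, a lower number a more polar compound. Compound 1, `CCCCCCS(=O)(=O)c1ccc(O)c(C(=O)Nc2ccc(Br)cc2)c1`, gives 5.2. Compound 3, `CCCCCCS(=O)(=O)c1ccc(O)c(C(=O)Nc2ccc(C(F)(F)F)cc2)c1`, gives 5.22. Compound 2, `CCCCCCCCCCCCS(=O)(=O)c1ccc(O)c(C(=O)Nc2ccc(C(F)(F)F)cc2)c1`, gives 8.46, the highest of the three. Compound 3 and compound 1 differ in a single place, (bromo in place of trifluoromethyl on an aromatic carbon), and that difference brings a step of a number 0.02 log units lower from compound 3 to compound 1 (within the scatter). Compound 3 and compound 2 differ in their cores, (hexyl in place of hydrogen on a saturated chain carbon, six bonds along the chain from a sulfonyl sulfur), and here the step is a number 3.24 log units lower from compound 2 to compound 3 (beyond the scatter). Compound 4, `CCCCCCCCCCCCS(=O)(=O)c1ccc(O)c(C(=O)Nc2ccc(Br)cc2)c1`, has not yet been measured in this assay. Going by the values given here, it differs from compound 2 by bromo in place of trifluoromethyl on an aromatic carbon, which is the same change, at the same place, as the one made from compound 3 to compound 1. A step of similar size is expected this time, a number 0.02 log units lower from compound 2 to compound 4 (within the scatter), because the earlier step of a number 0.02 log units lower from compound 3 to compound 1 (within the scatter) lay within the scatter. On that basis compound 4 is expected to give about 8.44 in this assay, with a likely range from 8.1 to 8.8.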

Compound 4, partition coefficient: 8.44
Compound 4: the middle estimate sits on the measured number at the digits printed; the measured number falls inside the stated range.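

In this assay the change from trifluoromethyl to bromo gives a step of a number 0.02 log units lower from compound 2 to compound 4 (within the scatter) on the core of compound 2, and a step of a number 0.02 log units lower from compound 3 to compound 1 (within the scatter) on the core of compound 1, so the two groups cannot be told apart in either pair. The change of chain carries over as well: the step of a number 3.24 log units higher from compound 1 to compound 4 (beyond the scatter) matches in size the step of a number 3.24 log units lower from compound 2 to compound 3 (beyond the scatter), which runs in the opposite direction, so the chain change has a step of the same size with either group on the aromatic ring. This shows agreement across just these two cores and says nothing of other cores or other assays, and nothing given here explains the agreement.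

Going by these compounds, it remains open whether an amine or a carboxylic acid in place of bromo would also leave this assay within the scatter. On these data alone, it is equally open whether a longer chain than that of compound 4 would extend the step seen with hexyl.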